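Methyl on the Phenyl Ring: What the Next Step Should Be

This account rests on a few compounds, and the source may have more. Where it says the series, first, only, none or still open, it means among the compounds named here.

Three compounds have been measured in a functional assay, with a stated time of 20 min, tested at 20 uM; a higher number here means a stronger effect of the compound at the concentration tested, a lower number a weaker effect:

compound 1, `COc1cc(/C=C/C(=O)C2=C(/C=C/c3ccc(O)c(OC)c3)NC(=O)NC2c2ccccc2)ccc1O`, gives 38.2%
compound 2, `COc1cc(/C=C/C(=O)C2=C(/C=C/c3ccc(O)c(OC)c3)NC(=O)NC2c2ccc(C)cc2)ccc1O`, gives 38.2%
compound 3, `COc1cc(/C=C/C(=O)C2=C(/C=C/c3ccc(O)c(OC)c3)NC(=S)NC2c2ccccc2)ccc1O`, gives 38%

Compound 1 and compound 2 share the same core and differ in one place only: methyl in place of hydrogen on an aromatic carbon. In this assay this change made no change at the digits printed from compound 1 to compound 2 (within the scatter). In plain terms, adding the methyl group at that spot left the read-out where it was.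

Compound 3 carries a different core from compound 1; the difference between the two cores is not broken down here. Its value and that of compound 1 lie within the scatter of each other, so nothing can be said about an order between them.

Compound 4, `COc1cc(/C=C/C(=O)C2=C(/C=C/c3ccc(O)c(OC)c3)NC(=S)NC2c2ccc(C)cc2)ccc1O`, has not yet been measured. It differs from compound 3 by methyl in place of hydrogen on an aromatic carbon. This is the same change that turns compound 1 into compound 2, and it sits at a place described in the same words for both pairs.

From compound 3 to compound 4 the step in this assay is expected to be no change at the digits printed from compound 3 to compound 4 (within the scatter), because the same change gave no change at the digits printed from compound 1 to compound 2 (within the scatter). That rests on one pair only, so the range is kept wide. For compound 4 in this assay the estimate is 38%, with a range from 29% to 47%.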

Compound 4, a percentage reported as activity, at one concentration (the size of the read-out at that concentration, not a potency): 51%
Compound 4: the middle estimate sits 13 percentage points below what was measured, and the stated range ends below it.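

In this assay, putting 4-methylphenyl in place of phenyl on the core of compound 3 gave a number 13 percentage points higher from compound 3 to compound 4 (beyond the scatter), while the same change on the core of compound 1 gave no change at the digits printed from compound 1 to compound 2 (within the scatter). Among the compounds shown here, one step lies beyond the usual scatter and the other within it, yet a gap between two steps carries the scatter of both, and here the gap is not large enough to separate them: the same change on two cores in this assay, no change at the digits printed (within the scatter) from compound 1 to compound 2 and a number 13 percentage points higher (beyond the scatter) from compound 3 to compound 4, 13 percentage points apart, within the scatter of two such steps So the results do not show that the methyl acts differently on the two cores, and they do not show that its step carries over unchanged from one core to the other either, since each core offers only a single pair.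

The compounds shown leave open what a different group at the same place on the phenyl ring, such as an ethyl, a methoxy group or a chlorine atom, would do on either core. They also leave open whether further pairs of phenyl and 4-methylphenyl on other cores would give steps closer to the one from the core of compound 1 or to the one from the core of compound 3.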